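Cyano Added to Compound 3

The source may report more compounds than this note shows. Statements on the series, on what has been measured and on what is new or still open speak of the compounds shown alone.

Compound 3 `Cc1ccccc1-c1cccc(C(=O)NCCCN2CCCC2)c1` gives 17400 nM in an assay on isolated protein for inhibition of N-lysine methyltransferase SMYD2 (Homo sapiens) (on this read-out lower numbers stand for stronger inhibition and higher numbers for weaker inhibition), the highest of the three numbers measured. Compound 2 `Cc1ccccc1-c1cc(C(=O)N2CCC(N3CCCCC3)CC2)c2cn[nH]c2n1` gives 16900 nM, which lies within the scatter of compound 3, so the two cannot be ordered. Compound 1 `Cc1ccccc1-c1cc(C(=O)NCC(Cc2ccccc2)CN2CCCC2)c2cn[nH]c2n1` gives 3600 nM, a step beyond the scatter toward stronger inhibition. Compound 4 `Cc1ccccc1-c1cc(C#N)cc(C(=O)NCCCN2CCCC2)c1` differs from compound 3 by cyano in place of hydrogen on an aromatic carbon. Among the compounds with values here, no measured pair shows this change, so its effect is open; the expected step is a 1.5-fold lower number from compound 3 to compound 4 (0.16 log units; within the scatter), small, toward stronger inhibition, and likely within the scatter. Compound 4 is therefore estimated at 12000 nM in this assay, with a range from 4000 nM to 35000 nM.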

Compound 4, half-maximal inhibitory concentration: 7300 nM
Compound 4: middle estimate off by 1.6-fold (0.22 log units), on the high side; measured number inside the range.
By their numbers in this assay, from the lowest: compound 1; then compound 4; then compounds 2 and 3 (each within the scatter of the next).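

Cyano in place of hydrogen on an aromatic carbon, meta to a 2-methylphenyl group, gives a 2.4-fold lower number from compound 3 to compound 4 (0.38 log units; beyond the scatter) in this assay. This is the only single-place change among the compounds shown, and it shows that this position accepts a group, with a modest shift toward stronger inhibition. Nothing measured here accounts for the step.

The compounds shown leave open whether another group at this position, such as fluorine, methoxy or a primary amide, would do the same. Going by these compounds, whether cyano would shift the number similarly on the core of compound 1 also stays open.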